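Adding a hydroxy to compound 3

The source may report more compounds than this note shows. Statements on the series, on what has been measured and on what is new or still open speak of the compounds shown alone.

In a functional assay on RAW264.7 cells (Mus musculus) for inhibition, read by Griess assay, with stated times of 2 h and 18 h (on this read-out higher numbers stand for weaker inhibition and lower numbers for stronger inhibition), compound 3 (`CC1=CC[C@H]2C(C)(C)CCC[C@]2(C)[C@H]1CC/C(C)=C/CO`) gives 20000 nM, the lowest number shown. Compound 2 (`CC1=CC[C@@H]2[C@](C)(CCC[C@]2(C)C(=O)O)[C@H]1CC/C(C)=C/CO`) gives 41100 nM, a gap to compound 3 beyond the scatter. Compound 1 (`COC(OC)[C@@]1(C)CCC[C@@]2(C)[C@H]1CC=C(C)[C@@H]2CC/C(C)=C/CO`) reads > 50000 nM, which is a limit of the assay and not a number. Compound 4 (`CC1=CC[C@H]2[C@@](C)(CO)CCC[C@]2(C)[C@H]1CC/C(C)=C/CO`) differs from compound 3 by hydroxy in place of hydrogen on a saturated chain carbon bound to a saturated ring carbon. For the measured compounds named here, the only measured step, an at least 1.2-fold lower number from compound 1 to compound 2 (0.08 log units; that floor lies within the scatter), involves other groups and offers little guidance. Compound 2 gives a weak hint, since at 41100 nM this carboxy compound has a higher number. A small rise is therefore expected in this assay, with the estimated change being a 1.4-fold higher number from compound 3 to compound 4 (0.13 log units; within the scatter), no clear shift beyond the scatter. Compound 4 is expected at about 27000 nM, within an estimated range of 11000 nM to 50000 nM.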

Compound 4, half-maximal inhibitory concentration: 33400 nM
For compound 4 the middle estimate is 1.2-fold (0.09 log units) below the measured one; the range from low to high includes it.
By their numbers in this assay, from the lowest: compounds 3, 4 and 2 (each within the scatter of the next, the first and the last beyond it). At a limit, above all of these: compound 1.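

In this assay, hydroxy in place of hydrogen on a saturated chain carbon bound to a saturated ring carbon gives a 1.7-fold higher number from compound 3 to compound 4 (0.22 log units; within the scatter), so this change produces no shift beyond the scatter. Hydroxymethyl in place of carboxy on a saturated ring carbon gives a 1.2-fold lower number from compound 2 to compound 4 (0.09 log units; within the scatter), so these two groups are not separated here. Hydroxymethyl in place of dimethoxymethyl gives an at least 1.4-fold lower number from compound 1 to compound 4 (0.17 log units; that floor lies within the scatter), and that floor rests on a limit of the assay: the limit of > 50000 nM in this assay, at which 1 of the 4 values shown sits.

From the compounds shown here alone, it remains open whether an amine at this place would move the number beyond the scatter. The same is open for a longer chain ending in hydroxy.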